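Swapping Methoxy for Difluoro on the Carbonyl-Bearing Ring

The source may hold more compounds than are shown below. What is called first, only, known or untested is meant among the compounds shown, and "the series" means these compounds.

Of the compounds shown here, three built on a shared core have been measured in a functional assay on UACC-257 cells (Homo sapiens) for inhibition, read by sulforhodamine B assay, with a stated time of 48 h; a lower number here means a stronger inhibitor of growth, a higher number a weaker inhibitor of growth. Compound 1 `COc1ccc(-c2cc(/C=C/C(=O)c3ccc(OC)c(OC)c3)[nH]n2)cc1` gives 3650 nM. Compound 2 `COc1cc(-c2cc(/C=C/C(=O)c3ccc(Cl)c(Cl)c3)[nH]n2)cc(OC)c1OC` gives 74000 nM. Compound 3 `COc1ccc(C(=O)/C=C/c2cc(-c3cc(OC)c(OC)c(OC)c3)n[nH]2)cc1` gives 3740 nM, the second highest of the three numbers; its nearest neighbour is compound 1, whose number sits within the usual scatter of it, and its furthest is compound 2. The only measured step that joins two of these compounds in one place is a 20-fold lower number from compound 2 to compound 3 (1.30 log units; beyond the scatter), in which a 4-methoxyphenyl took the place of a 3,4-dichlorophenyl on a carbonyl carbon.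

Compound 4 `COc1cc(-c2cc(/C=C/C(=O)c3ccc(F)c(F)c3)[nH]n2)cc(OC)c1OC` has not yet been measured. It differs from compound 3 in a single place: 3,4-difluorophenyl in place of 4-methoxyphenyl on a carbonyl carbon. This is close to a reversal of that measured step, because a 20-fold lower number from compound 2 to compound 3 (1.30 log units; beyond the scatter) was large and ran toward a lower number when the 4-methoxyphenyl entered; taking the 4-methoxyphenyl out again and putting in a 3,4-difluorophenyl is therefore expected to move the number upward in this assay, though fluorine is not chlorine, so the size is less certain. Compound 4 is expected to give about 20000 nM, with a range from 7000 nM to 60000 nM. The expected step is a 5.3-fold higher number from compound 3 to compound 4 (0.73 log units; beyond the scatter).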

Compound 4, concentration for total growth inhibition: 6280 nM
Compound 4: the middle estimate sits 3.2-fold (0.50 log units) above what was measured, outside the stated range (below it).
By their numbers in this assay, from the lowest: compounds 1, 3 and 4 (each within the scatter of the next); then compound 2.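

On the carbonyl carbon of the shared core, in this assay the change from 4-methoxyphenyl to 3,4-difluorophenyl gives a 1.7-fold higher number from compound 3 to compound 4 (0.23 log units; within the scatter) and so leaves the two groups indistinguishable here. A ring with no methoxy group can therefore sit at this place without the weak growth inhibition seen for compound 2, something the earlier step from compound 2 to compound 3 could not show on its own, and the change from 3,4-dichlorophenyl to 3,4-difluorophenyl gives a 12-fold lower number from compound 2 to compound 4 (1.07 log units; beyond the scatter) on an otherwise unchanged structure, which ties the large gap to chlorine versus fluorine on this ring and not to the missing methoxy group. No measurement is available that would explain why these two halogens differ so sharply at this place.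

As far as these compounds go, whether a ring with a single fluorine, a carboxylic acid or a dimethylamino group at this place would fall with compound 3 and compound 4 or with compound 2 stays open. Also open, from the compounds shown here alone, is whether the contrast between chlorine and fluorine would hold on a core changed elsewhere.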